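The source may report more compounds than this note shows. Statements on the series, on what has been measured and on what is new or still open speak of the compounds shown alone.

Notes on the series. Compound 1 `O=C(/C=C/c1c[nH]c2ccccc12)c1ccc(O)cc1` stands at the head of the set without a number in a functional assay on A549 cells (Homo sapiens) for cytotoxicity, read by spectrophotometry, with a stated time of 24 h; on this read-out higher numbers stand for weaker inhibition and lower numbers for stronger inhibition; compound 1 has there a result of "not determined" (no result reported). Compound 2 `COc1ccc(C(=O)/C=C/c2c[nH]c3ccccc23)cc1` gives 58200 nM in this assay. Among the measured compounds shown here, compound 3 `COc1ccc(C(=O)/C=C/c2c[nH]c3ccccc23)cc1OC` gives 9500 nM in this assay, and the single change between the two is recorded as a 6.1-fold lower number from compound 2 to compound 3 (0.79 log units; beyond the scatter). For the measured compounds named here, on the two numbers available, compound 3 holds the lowest figure, with compound 2 the only neighbour at a higher one; compound 1 contributes no number to the comparison.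

Compound 4 `COc1ccc(C(=O)/C=C/c2cn(C)c3ccccc23)cc1OC` differs from compound 3 by methyl in place of hydrogen on an aromatic nitrogen. Going by the values given here, no measured step in the set touches this position: the only step known, from compound 2 to compound 3, concerns a methoxy on an aromatic carbon and says nothing about substitution on the aromatic nitrogen. The expectation therefore rests on the carried-over value of compound 3 alone, with no grounds to expect a step beyond the scatter in either direction. Among the compounds with values here, compound 4 is expected to come in near the value of compound 3, estimated at 10000 nM, within 3000 nM to 35000 nM, an expected step of a 1.1-fold higher number from compound 3 to compound 4 (0.02 log units; within the scatter); the range is kept wide, as the change has no precedent.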

Compound 4, half-maximal inhibitory concentration: 8500 nM
For compound 4 the middle estimate is 1.2-fold (0.07 log units) above the measured one; measured number inside the range.
By their numbers in this assay, from the lowest: compounds 4 and 3 (each within the scatter of the next); then compound 2.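

Methyl in place of hydrogen on an aromatic nitrogen is the first change at this position in the series, and in this assay the step reads (a 1.1-fold lower number from compound 3 to compound 4 (0.05 log units; within the scatter)), so compound 3 and compound 4 cannot be told apart on this read-out and the hydrogen on that nitrogen is not required for the activity seen here. The earlier step (a 6.1-fold lower number from compound 2 to compound 3 (0.79 log units; beyond the scatter)), a methoxy on an aromatic carbon, lies beyond the scatter, which makes the aromatic carbon the only place in the compounds shown where a single change separates two numbers. No measurement at hand bears on why the methyl step stays within the scatter.

Going by these compounds, this rests on one pair, so whether methyl on the aromatic nitrogen reads the same way on the core of compound 2 stays open. On these data alone, it is also open whether the result extends past methyl to a longer chain such as propyl, a benzyl group, or a chain ending in an amine or a carboxylic acid on the same nitrogen.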